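Moving the fluorine on the aryl ring of compound 2

A few compounds are considered here, and "the series" means these few. Any claim that something is new, unique, unknown or untested is made for them only; others in the source may bear on it.

compound 1 `COc1ccc(/C=C/C(=O)c2ccccc2-c2ccc(F)cc2)cc1`: 61 nM
compound 2 `COc1ccc(/C=C/C(=O)c2ccccc2-c2ccc(F)cc2)cc1OC`: 570 nM
compound 3 `COc1cc(/C=C/C(=O)c2ccccc2-c2ccc(F)cc2)ccc1O`: 6600 nM

In a functional assay on SW480 cells (Homo sapiens) for antiproliferative activity, read by sulforhodamine B assay, with a stated time of 48 h (on this read-out higher numbers stand for weaker inhibition and lower numbers for stronger inhibition), compound 2 gives 570 nM, the second highest of the three numbers. Its neighbours lie on either side of it, and both gaps are beyond the scatter.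

Compound 4 `COc1ccc(/C=C/C(=O)c2ccccc2-c2cccc(F)c2)cc1OC` is derived from compound 2 by one change: 3-fluorophenyl in place of 4-fluorophenyl on an aromatic carbon. Among the measured compounds shown here, no measured step tests this change. The two available steps, a 9.3-fold higher number from compound 1 to compound 2 (0.97 log units; beyond the scatter) and a 12-fold higher number from compound 2 to compound 3 (1.06 log units; beyond the scatter), both keep the 4-fluorophenyl in place and alter the other aromatic ring. They therefore give no direction for the new step. They show only that single small edits in these three compounds moved this assay well beyond the scatter, so the range must stay wide. With no direction supported, no shift beyond the scatter is expected, and the expected step is a 1.1-fold higher number from compound 2 to compound 4 (0.02 log units; within the scatter). For compound 4 the estimated value is 600 nM, with an expected range of 150 nM to 2500 nM.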

Compound 4, half-maximal inhibitory concentration: 160 nM
Compound 4: middle estimate off by 3.8-fold (0.57 log units), on the high side, and the stated range covers the measured number.
By their numbers in this assay, from the lowest: compound 1; then compound 4; then compound 2; then compound 3.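

Moving the fluorine, so that 3-fluorophenyl stands in place of 4-fluorophenyl, gives in this assay a 3.6-fold lower number from compound 2 to compound 4 (0.55 log units; beyond the scatter), the first step shown on this aryl ring. The ring stayed fixed across compound 1, compound 2 and compound 3, and this step shows that it is not indifferent: with the same atoms joined differently, the place of a single fluorine alone moves the number beyond the scatter, here towards stronger inhibition. Nothing available bears on why the change has this effect.

From the compounds shown here alone, whether the same move would also lower the number when made on compound 1 or on compound 3 remains open. Also open, going by these compounds, is how this place on the ring would respond to a group other than fluorine, such as an amine or a carboxylic acid.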